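Furan to Methylthiazole on the Shared Core

This account rests on a few compounds, and the source may have more. Where it says the series, first, only, none or still open, it means among the compounds named here.

Three compounds built on the shared core of compound 1 `Cc1cccc(-c2ccccc2OCC2=NCCN2)n1` have been measured in a functional assay for activation of Alpha-1A adrenergic receptor (Homo sapiens), read by calcium flux; a lower number here means that less compound is needed, a higher number that more compound is needed for the effect. Compound 1 gives 126 nM. Compound 2 `c1csc(-c2ccccc2OCC2=NCCN2)c1`, carrying thiophen-2-yl, gives 1 nM in this assay, and compound 3 `c1ccc(-c2ccoc2)c(OCC2=NCCN2)c1`, carrying furan-3-yl, gives 0.501 nM. Going by the values given here, the only single-point step among them, a 2.0-fold lower number from compound 2 to compound 3 (0.30 log units; within the scatter), shows that exchanging one five-membered ring for another left the number essentially where it was. Compound 3 thus holds the lowest number of the three, yet its separation from compound 2 lies within the scatter, while compound 1 sits far higher.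

Compound 4 `Cc1cnsc1-c1ccccc1OCC1=NCCN1` changes compound 3 at one place: 4-methyl-1,2-thiazol-5-yl in place of furan-3-yl on an aromatic carbon. Two things bear on this. The step from compound 2 to compound 3 says that swapping five-membered aromatic rings with one hetero atom costs little. The values of compound 1 and compound 3, taken side by side, show that a ring with nitrogen and a methyl can go with a much higher number, though compound 1 differs in ring size too. He therefore expects a modest rise, a 6.0-fold higher number from compound 3 to compound 4 (0.78 log units; beyond the scatter), with wide uncertainty. His estimate for compound 4 in this assay is 3 nM, between 0.5 nM and 20 nM.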

Compound 4, half-maximal effective concentration: 12.6 nM
Compound 4: the middle estimate sits 4.2-fold (0.62 log units) below what was measured; low and high end bracket the measured number.
By their numbers in this assay, from the lowest: compounds 3 and 2 (each within the scatter of the next); then compound 4; then compound 1.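

At this position, on an aromatic carbon of the shared core, the identity of the five-membered aromatic ring can matter in this assay, which the earlier exchange of furan-3-yl for thiophen-2-yl could not show (a 2.0-fold lower number from compound 2 to compound 3 (0.30 log units; within the scatter)). Moving to 4-methyl-1,2-thiazol-5-yl gives a 25-fold higher number from compound 3 to compound 4 (1.40 log units; beyond the scatter) and likewise a 13-fold higher number from compound 2 to compound 4 (1.10 log units; beyond the scatter), so both five-membered rings with low numbers part clearly from the entering group, although the printed values still place compound 4 at 12.6 nM and compound 1 higher at 126 nM. No measurement on record accounts for the size of these steps.

The entering group adds a methyl and a ring nitrogen in a single change, so the compounds shown leave open how much of the rise belongs to each of them. A plain 1,2-thiazol-5-yl without the methyl would separate the two, and an ethyl or a methoxy in place of that methyl would show whether the number follows what is attached to the ring.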